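The source may hold more compounds than are shown below. What is called first, only, known or untested is meant among the compounds shown, and "the series" means these compounds.

Measured compounds in an assay on cell membranes from spleen (Cavia porcellus) for binding affinity to leukotriene B4 receptor 1 (Homo sapiens); a lower number here means a stronger inhibitor, a higher number a weaker inhibitor:
compound 1 `COC(=O)CCCCCOc1cc(-c2ccccc2)cc(-c2ccccc2)n1`: 40 nM
compound 2 `O=C(O)CCCCCOc1cc(-c2ccccc2Cl)cc(-c2ccccc2)n1`: 200 nM
compound 3 `CC(C)(CCCCCCOc1cc(-c2ccccc2)cc(-c2ccccc2)n1)C(=O)O`: 22 nM

Compound 2 gives the highest number of the three in this assay; compound 1 sits lower and compound 3 lower still, both gaps beyond the scatter. For the measured compounds named here, the only step between compounds differing in one place, a 1.8-fold lower number from compound 1 to compound 3 (0.26 log units; within the scatter), concerns the chain end and lies within the scatter. Compound 2 and compound 1 differ in two places, so their values show only that the carboxylic acid chain end together with the 2-chlorophenyl group gave a higher number than the methoxycarbonyl chain end with two phenyl groups.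

Compound 4 `O=C(O)CCCCCOc1cc(-c2ccc(C(F)(F)F)cc2)cc(-c2ccccc2)n1` is not yet measured. It differs from compound 2 as follows: 4-(trifluoromethyl)phenyl in place of 2-chlorophenyl on an aromatic carbon. Going by the values given here, no measured step bears on this change: none of the three compounds carries a 4-(trifluoromethyl)phenyl group, and no measured pair differs only in the substituent on that ring. The expectation rests on the spread of the values alone. Compound 4 is therefore expected to give a step of a 2.0-fold lower number from compound 2 to compound 4 (0.30 log units; within the scatter), carrying considerable uncertainty. In this assay compound 4 is estimated at 100 nM, within a range of 30 nM to 400 nM.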

Compound 4, half-maximal inhibitory concentration: 10 nM
For compound 4 the middle estimate is 10-fold (1.00 log units) above the measured one, and the stated range ends above it.
By their numbers in this assay, from the lowest: compound 4; then compounds 3 and 1 (each within the scatter of the next); then compound 2.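

On the aromatic carbon opposite the ring nitrogen, replacing 2-chlorophenyl with 4-(trifluoromethyl)phenyl gives a 20-fold lower number from compound 2 to compound 4 (1.30 log units; beyond the scatter) in this assay with the (5-carboxypentyl)oxy group and the phenyl group unchanged. For the compounds shown here, this position therefore responds strongly to the choice of aryl substituent, something the earlier compounds could not show, as their only one-place step concerned the chain end and stayed within the scatter: a 1.8-fold lower number from compound 1 to compound 3 (0.26 log units; within the scatter). Nothing available explains the size of the new step.

From the compounds shown here alone, the step changes the substituent and its ring position together, so it remains open whether the chlorine raises the number, the trifluoromethyl group lowers it, or both contribute; an unsubstituted phenyl group at this position with the same carboxylic acid chain, together with 4-chlorophenyl and 2-(trifluoromethyl)phenyl groups, would separate these effects. Also open, going by these compounds, is whether the 4-(trifluoromethyl)phenyl group gives a comparable step when paired with the longer gem-dimethyl acid chain of compound 3, or whether a nitrile or methoxy group at the same ring position would match it.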